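A Bromine Enters the Ethyl Chain of Compound 3

The compounds below may be only part of what the source reports. "The series", "measured", "known", "first", "only" and "open" are said of these compounds alone.

Compound 1 `CCc1oc2c(C)c(OC(C)C)ccc2c(=O)c1Br`: 22600 nM
Compound 2 `CCc1cc(=O)c2ccc(OC(C)C)c(CBr)c2o1`: > 30700 nM (a limit of the assay)
Compound 3 `CCc1cc(=O)c2ccc(OCC(C)C)c(CBr)c2o1`: > 29400 nM (a limit of the assay)

In a functional assay on KB cells (Homo sapiens) for antiproliferative activity, read by sulforhodamine B assay, with a stated time of 72 h (a higher number here means a weaker inhibitor of growth, a lower number a stronger inhibitor of growth), compound 1 gives 22600 nM. For compound 2 the assay returns only a limit, > 30700 nM. For compound 3 the assay likewise returns only a limit, > 29400 nM. Compound 3 therefore sits at one of the two limits among the three values, the limit of > 29400 nM in this assay, at which 1 of the 3 values shown sits, alongside (the limit of > 30700 nM in this assay, at which 1 of the 3 values shown sits), and no number places it relative to compound 1. Within the data shown here, the single measured step, a step that the two limits leave unreadable from compound 2 to compound 3, runs between two limits and cannot be read.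

Compound 4 `CC(C)COc1ccc2c(=O)cc(C(C)Br)oc2c1CBr` differs from compound 3 by bromo in place of hydrogen on a saturated chain carbon bound to an aromatic carbon and a saturated chain carbon. Among the measured compounds shown here, no measured step concerns this change; the one measured step touches the oxygen substituent and is unreadable. Compound 1 carries a bromo elsewhere, on the core, but differs from compound 3 in more than one place, so only its value can be noted. The estimated step that the limit leaves unreadable from compound 3 to compound 4 is expected to stay within the scatter. Compound 4 is thus expected to give about 30000 nM, in the range 8000 nM to 60000 nM, most likely again as a limit in this assay.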

Compound 4, concentration for 50% growth inhibition: 10900 nM
Beside the measured number, compound 4's estimate is 2.8-fold (0.44 log units) above it, and the stated range covers the measured number.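

Placing bromo on a saturated chain carbon bound to an aromatic carbon and a saturated chain carbon, which turns ethyl into 1-bromoethyl, gives the first step in this assay that can be read, an at least 2.6-fold lower number from compound 3 to compound 4 (0.43 log units; beyond the scatter). Only a lower bound on its size can be given, since compound 3 stands at a limit of the assay: the limit of > 29400 nM in this assay, at which 1 of the 4 values shown sits. Among these compounds, the earlier compounds said nothing about this position, for the one earlier step concerns the oxygen substituent and cannot be read.

The compounds shown leave open whether a chloro, a hydroxyl or an amine on this same carbon would give a step of similar size. They also leave open whether the step would hold with isopropyl in place of isobutyl on the oxygen, and how large it truly is.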